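Thiophen-2-yl to thiophen-3-yl swap across two related cores

A few compounds are considered here, and "the series" means these few. Any claim that something is new, unique, unknown or untested is made for them only; others in the source may bear on it.

Compound 1 `CC1=C(C(=O)OC(C)(C)C)C(c2cccs2)NC(=S)N1` gives 22% in an assay on membranes from HeLa cells for displacement of a labelled ligand from adenosine receptor A3 (Homo sapiens), read by scintillation counting, with a stated time of 180 min, tested at 1 uM; a lower number here means less inhibition, a higher number more inhibition at the concentration tested (going by the name of the read-out). Its regioisomer compound 2 `CC1=C(C(=O)OC(C)(C)C)C(c2ccsc2)NC(=S)N1` gives 16% in this assay, and the move thiophen-3-yl in place of thiophen-2-yl on a saturated ring carbon produces a number 6 percentage points lower from compound 1 to compound 2 (within the scatter). Compound 3 `COC(=O)C1=C(C)N(C)C(=O)NC1c1cccs1` carries a different core; how it departs from the core of compound 1 is not broken down here. In this assay compound 3 gives 15%, which sits within the scatter of both compound 1 and compound 2.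

Compound 4 `COC(=O)C1=C(C)N(C)C(=O)NC1c1ccsc1` is not yet measured. It differs from compound 3 by thiophen-3-yl in place of thiophen-2-yl on a saturated ring carbon, the same kind of change as that from compound 1 to compound 2, though the surroundings differ: in compound 3 the saturated ring carbon is next to the ring atom that bears a methoxycarbonyl group (4 heavy atoms) and three ring bonds from the ring atom that bears a methyl group (1 heavy atom), whereas in compound 1 it is next to the ring atom that bears a group of 7 heavy atoms. Because the earlier step was a number 6 percentage points lower from compound 1 to compound 2 (within the scatter), the step from compound 3 to compound 4 is expected to be a number 3 percentage points lower from compound 3 to compound 4 (within the scatter). Compound 4 is thus estimated at 12%, between 2% and 24%.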

Compound 4, a percentage reported as inhibition, at one concentration (the size of the read-out at that concentration, not a potency): 22%
The estimate for compound 4 lay 10 percentage points below the measured number, and the stated range covers the measured number.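

In this assay, thiophen-3-yl in place of thiophen-2-yl on the saturated ring carbon gives a number 7 percentage points higher from compound 3 to compound 4 (within the scatter). Set beside the same change on the core of compound 1, the two steps cannot be told apart: the same change on two cores in this assay, a number 6 percentage points lower (within the scatter) from compound 1 to compound 2 and a number 7 percentage points higher (within the scatter) from compound 3 to compound 4, 13 percentage points apart, within the scatter of two such steps. The pair therefore gives no sign that the core alters the outcome of this swap, but it does not establish that the swap transfers unchanged from one core to the other, as neither step is distinguishable from repeat-measurement noise and a reading at one concentration is not a potency.

Still open, from the compounds shown here alone, is whether a different group on the saturated ring carbon, such as phenyl, or a carboxylic acid in place of the methoxycarbonyl group, would shift the inhibition beyond the scatter. Also open is which of the differences between the two cores would matter for this swap, as no pair shown isolates any one of them.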